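A few compounds are considered here, and "the series" means these few. Any claim that something is new, unique, unknown or untested is made for them only; others in the source may bear on it.

Compound 1 `CC(C(=O)NCc1ccc(C(C)(C)C)nc1OCc1ccccc1)c1ccc(NS(C)(=O)=O)c(F)c1` is measured in an assay on cells for antagonist activity at transient receptor potential cation channel subfamily V member 1 (Homo sapiens), read by FLIPR and calcium flux, with a stated time of 6 min (a lower number here means a stronger inhibitor, a higher number a weaker inhibitor), where compound 1 gives 4.4 nM. Compound 2 `CC(C(=O)NCc1ccc(C(C)(C)C)nc1OCc1ccc(F)cc1)c1ccc(NS(C)(=O)=O)c(F)c1` differs from compound 1 in one place, (fluoro in place of hydrogen on an aromatic carbon), and in this assay compound 2 gives 0.8 nM, which is a 5.5-fold lower number from compound 1 to compound 2 (0.74 log units; beyond the scatter). Compound 3 `CC(C(=O)NCc1ccc(C(C)(C)C)cc1OCc1ccccc1)c1ccc(NS(C)(=O)=O)c(F)c1` is built on a different core; the difference between the two cores is not broken down here. In this assay compound 3 gives 2.9 nM, a number close to that of compound 1. Compound 4 `CC(C(=O)NCc1ccc(C(C)(C)C)cc1OCc1ccc(F)cc1)c1ccc(NS(C)(=O)=O)c(F)c1` has not yet been measured. It stands to compound 3 exactly as compound 2 stands to compound 1: the change is fluoro in place of hydrogen on an aromatic carbon, at the same place on the same kind of ring, so it is the same change seen once already. That earlier step was made on a different core, and its size may not carry over fully. Within the data shown here, it is nonetheless the only guide available. The step expected is a 4.1-fold lower number from compound 3 to compound 4 (0.62 log units; beyond the scatter), resting on the earlier step of a 5.5-fold lower number from compound 1 to compound 2 (0.74 log units; beyond the scatter). Compound 4 is therefore expected to give about 0.7 nM, with a likely range from 0.25 nM to 2 nM.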

Compound 4, inhibition constant: 3.8 nM
Beside the measured number, compound 4's estimate is 5.4-fold (0.73 log units) below it; measured number outside the range, above it.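

In this assay, changing benzyl to 4-fluorobenzyl on the core of compound 3 gives a 1.3-fold higher number from compound 3 to compound 4 (0.12 log units; within the scatter), so on this core the added fluoro makes no clear difference. Set beside the earlier step, the same change does not behave alike on the two cores: the same change on two cores in this assay, a 5.5-fold lower number (0.74 log units; beyond the scatter) from compound 1 to compound 2 and a 1.3-fold higher number (0.12 log units; within the scatter) from compound 3 to compound 4, 7.2-fold (0.86 log units) apart, beyond the scatter of two such steps. Among these compounds, this shows that the gain seen on the core of compound 1 cannot simply be assumed to carry over to the core of compound 3, but with only one pair on each core, it does not show why the two steps differ or what the change would do on any further core.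

The compounds shown leave open whether this split belongs to fluoro alone or would also appear with a chlorine atom, a methyl group or a methoxy group in its place. Also open, from the compounds shown here alone, is whether the two cores would part ways again if the benzyloxy group gave way to a longer chain or an amine.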